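The source may report more compounds than this note shows. Statements on the series, on what has been measured and on what is new or still open speak of the compounds shown alone.

Measured in a functional assay on HL-60 cells (Homo sapiens) for cytotoxicity, read by MTT assay, with a stated time of 3 days; on this read-out higher numbers stand for weaker inhibition and lower numbers for stronger inhibition:

- compound 1 `N#Cc1c(O)nc(SCc2nc3ccccc3[nH]2)nc1-c1ccccc1`: 2.55 nM
- compound 2 `N#Cc1c(Cl)nc(SCc2nc3ccccc3[nH]2)nc1-c1ccccc1`: 4.46 nM
- compound 3 `CCNc1nc(SCc2nc3ccccc3[nH]2)nc(-c2ccccc2)c1C#N`: 3.96 nM

Compound 3 cannot be separated from the other two on these numbers, since its value lies within the scatter of both. Compound 4 `N#Cc1c(NC(N)=S)nc(SCc2nc3ccccc3[nH]2)nc1-c1ccccc1` keeps the shared core of compound 3 but changes the ethylamino group. On the nitrogen on an aromatic ring, ethyl leaves and a group of 3 heavy atoms (1 carbon, 1 nitrogen, 1 sulfur; no ring) enters: a group of 3 heavy atoms (1 carbon, 1 nitrogen, 1 sulfur; no ring) in place of a group of 2 heavy atoms (2 carbon; no ring), on a nitrogen on an aromatic ring.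

The nearest evidence comes from swapping groups on an aromatic carbon at this same spot on the core. These swaps gave a 1.7-fold higher number from compound 1 to compound 2 (0.24 log units; within the scatter), a 1.6-fold higher number from compound 1 to compound 3 (0.19 log units; within the scatter) and a 1.1-fold lower number from compound 2 to compound 3 (0.05 log units; within the scatter), and all three stayed within the scatter. Within the data shown here, no measured step tests the new group itself, so this evidence is only indirect. Going by those small steps, the expected change is a 1.0-fold higher number from compound 3 to compound 4 (0.00 log units; within the scatter), with no shift beyond the scatter anticipated. For compound 4 the estimate is 4 nM, with an expected range from 1.5 nM to 12 nM.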

Compound 4, half-maximal inhibitory concentration: 5.81 nM
Compound 4: middle estimate off by 1.5-fold (0.16 log units), on the low side; the measured number falls inside the stated range.
By their numbers in this assay, from the lowest: compounds 1, 3, 2 and 4 (each within the scatter of the next, the first and the last beyond it).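

In this assay, putting the group of 3 heavy atoms (1 carbon, 1 nitrogen, 1 sulfur; no ring) on the nitrogen in place of ethyl gave a 1.5-fold higher number from compound 3 to compound 4 (0.17 log units; within the scatter) and the same spot held chloro in the step that gave a 1.3-fold higher number from compound 2 to compound 4 (0.11 log units; within the scatter), so compound 4 cannot be separated from compound 3 or compound 2. Among these compounds, the step that gave a 2.3-fold higher number from compound 1 to compound 4 (0.36 log units; beyond the scatter) is modest, yet it is the first at this spot to pass the scatter, which makes hydroxy and the new group the first pair here that can be told apart. Nothing measured here explains these differences.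

The compounds shown leave open whether a plain amine or a longer chain such as butyl on this nitrogen would keep the number in the same narrow band. They also leave open whether a methoxy or a carboxylic acid on the aromatic carbon would move it further.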